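The source may report more compounds than this note shows. Statements on the series, on what has been measured and on what is new or still open speak of the compounds shown alone.

In a functional assay on SW480 cells (Homo sapiens) for antiproliferative activity, read by MTT assay, with a stated time of 48 h (on this read-out lower numbers stand for stronger inhibition and higher numbers for weaker inhibition), compound 1 `CCCCCC(CCO)n1cnc2c(N)ncnc21` reaches only a limit, > 50000 nM. Compound 2 `CCCCCCCCCC(CCO)n1cnc2c(N)ncnc21` gives 6030 nM and compound 3 `CCCCCCCCCCCC(CCO)n1cnc2c(OC)ncnc21` gives 9700 nM, two values within the scatter of each other. Compound 4 `CCCCCCCCCCCC(CCO)n1cnc2c(N)ncnc21` keeps the chain of compound 3 and differs by amino in place of methoxy on an aromatic carbon. Going by the values given here, the only measured step, an at least 8.2-fold lower number from compound 1 to compound 2 (0.91 log units; beyond the scatter), is butyl in place of hydrogen on a saturated chain carbon; it rests on the limit of > 50000 nM in this assay, at which 1 of the 3 values shown sits, and does not cover this exchange. Compound 2, which carries amino, gives 6030 nM, so no change beyond the scatter is expected in this assay. The expected change is a 1.9-fold lower number from compound 3 to compound 4 (0.29 log units; within the scatter). For compound 4 the estimate is 5000 nM, with an expected range of 1800 nM to 13000 nM.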

Compound 4, half-maximal inhibitory concentration: 11600 nM
Compound 4: middle estimate off by 2.3-fold (0.37 log units), on the low side; the range from low to high includes it.
By their numbers in this assay, from the lowest: compounds 2, 3 and 4 (each within the scatter of the next). At a limit, above all of these: compound 1.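

In this assay, amino in place of methoxy on an aromatic carbon gives no change beyond the scatter (a 1.2-fold higher number from compound 3 to compound 4 (0.08 log units; within the scatter)), so this exchange at this position does not separate the two groups. The added ethyl on the chain also stays within the scatter (a 1.9-fold higher number from compound 2 to compound 4 (0.28 log units; within the scatter)), so the drop seen from compound 1 to compound 2 does not carry on to compound 4. The hexyl step (an at least 4.3-fold lower number from compound 1 to compound 4 (0.63 log units; beyond the scatter)) lies beyond the scatter but gives only a bound, since compound 1 stands at a limit: the limit of > 50000 nM in this assay, at which 1 of the 4 values shown sits.

As far as these compounds go, whether a longer chain would shift the number in this assay stays open. So does whether a chlorine or a methylamino group on that aromatic carbon would differ from amino and methoxy.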